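A few compounds are considered here, and "the series" means these few. Any claim that something is new, unique, unknown or untested is made for them only; others in the source may bear on it.

Measured compounds:
compound 1, `COc1cc(C)cc(-c2c(-c3ccnc(-c4ccc(N(C)C)cc4)c3)cnn2CC#N)c1`: > 100000 nM
compound 2, `COc1cc(C)cc(-c2nn(CC#N)cc2-c2ccc(-c3cccc(C(C)=O)c3)nc2)c1`: 84000 nM
compound 3, `Cc1cc(O)cc(-c2nn(CC#N)cc2-c2ccnc(-c3ccc(N(C)C)cc3)c2)c1`: 24800 nM

In a functional assay on NCI-H23 cells (Homo sapiens) for inhibition, read by sulforhodamine B assay, with a stated time of 48 h (a higher number here means a weaker inhibitor of growth, a lower number a stronger inhibitor of growth), compound 1 gives only > 100000 nM, which is a limit of the assay and not a number. That limit is the assay's own ceiling: the limit of > 100000 nM in this assay, at which 1 of the 3 values shown sits. Compound 2 gives 84000 nM in this assay. Compound 3 gives 24800 nM in this assay. Among the measured compounds shown here, neither compound 2 nor compound 3 differs from compound 1 in a single place, so no step between measured compounds is drawn here, and only the bare values are known.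

Compound 4, `COc1cc(C)cc(-c2c(-c3ccnc(-c4ccc(C(C)=O)cc4)c3)cnn2CC#N)c1`, is not yet measured in this assay. It differs from compound 1 by acetyl in place of dimethylamino on an aromatic carbon. With compound 1 standing only at a limit, the step cannot be set against a measured number, and the expectation is for no step beyond the scatter, with compound 4 most likely at or close to the limit as well. Compound 2, which also carries an acetyl group, gives 84000 nM, which leaves room for a weak but countable growth inhibitor.

Compound 4 is expected at 100000 nM in this assay, with a range from 30000 nM to 300000 nM. This amounts to an expected step of a number no higher from compound 1 to compound 4 (the limit leaves the size open), that is, none beyond the scatter.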

Compound 4, concentration for total growth inhibition: > 100000 nM
Compound 4 ended at the assay's limit (the forecaster's own chance of this, stated with the estimate: 55%); the middle value lies on the limit itself.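

Compound 1 and compound 4 both sit at a limit of this assay and not at a number, so no step between them can be read: the limit of > 100000 nM in this assay, at which 2 of the 4 values shown sit.

Still open, on these data alone, is whether acetyl in place of dimethylamino on the core of compound 1 changes growth inhibition at all in this assay.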